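(Nitrooxy)methyl on the amide nitrogen of compound 2

The source may hold more compounds than are shown below. What is called first, only, known or untested is meant among the compounds shown, and "the series" means these compounds.

In a functional assay on CLL cells (Homo sapiens) for cytotoxicity, read by MTT assay, with a stated time of 48 h (a higher number here means that more compound is needed for the effect, a lower number that less compound is needed), compound 2 `C=C(CC)C(=O)c1ccc(OCC(=O)Nc2ccc(O)c(Cl)c2)c(Cl)c1Cl` gives 5500 nM, within the scatter of compound 1 `C=C(CC)C(=O)c1ccc(OCC(=O)NC(CS)C(=O)OCC)c(Cl)c1Cl` at 4800 nM. Compound 3 `C=C(CC)C(=O)c1ccc(OCC(=O)NCO[N+](=O)[O-])c(Cl)c1Cl` carries (nitrooxy)methyl in place of 3-chloro-4-hydroxyphenyl on an amide-type nitrogen. For the measured compounds named here, the only measured step on that nitrogen, a 1.1-fold higher number from compound 1 to compound 2 (0.06 log units; within the scatter), stayed within the scatter, but it involves no (nitrooxy)methyl, so it is a weak guide. No step beyond the scatter is therefore expected in this assay, with a wide margin in either direction. The estimated step is a 1.2-fold lower number from compound 2 to compound 3 (0.09 log units; within the scatter). For compound 3 the expected value is 4500 nM, with an estimated range of 1500 nM to 13000 nM.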

Compound 3, half-maximal effective concentration: 4100 nM
Compound 3: the middle estimate sits 1.1-fold (0.04 log units) above what was measured, within the range that was stated.
By their numbers in this assay, from the lowest: compounds 3, 1 and 2 (each within the scatter of the next).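

In this assay, putting (nitrooxy)methyl on the amide-type nitrogen gives a 1.3-fold lower number from compound 2 to compound 3 (0.13 log units; within the scatter) and a 1.2-fold lower number from compound 1 to compound 3 (0.07 log units; within the scatter). Three quite different groups on this nitrogen therefore read alike, and neither a hydroxy-bearing aromatic ring nor a sulfanyl-bearing chain is required for this level of cytotoxicity. No measured evidence bears on the cause of this flat response.

Still open, going by these compounds, is whether a carboxylic acid, an amine or a longer nitrooxyalkyl chain on this nitrogen would give a step beyond the scatter. The three compounds also leave open whether changes elsewhere on the shared core would do so.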